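A few compounds are considered here, and "the series" means these few. Any claim that something is new, unique, unknown or untested is made for them only; others in the source may bear on it.

Measured so far:
compound 1, `N#CC1CN1C(=O)NCc1ccccc1`, 11000 nM
compound 2, `N#CC1CN1C(=O)Nc1ccc([N+](=O)[O-])cc1`, 8600 nM
compound 3, `N#CC1CN1C(=O)NC1CCCCC1`, 98000 nM

In a functional assay on RPMI-8226 cells (Homo sapiens) for inhibition (a lower number here means a stronger inhibitor, a higher number a weaker inhibitor), compound 2 gives the lowest of the three numbers at 8600 nM. Its nearest neighbour is compound 1 with 11000 nM, a gap that lies within the usual scatter, so no order between compound 1 and compound 2 can be read from these two values. Compound 3 stands furthest away with 98000 nM, a gap beyond the scatter. All three carry the shared core and differ only in the group on the urea nitrogen.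

The step followed here leads from compound 2 to compound 4, `N#CC1CN1C(=O)Nc1ccc(F)cc1`, which has not yet been measured in this assay. The change is fluoro in place of nitro on an aromatic carbon. Among the compounds with values here, no measured pair shows this change, so its effect cannot be read from the data. Since compound 2, the only aryl urea measured, gives 8600 nM and the nitro group is the sole point of difference, a modest step in this assay is expected, towards a higher number, of a size that may or may not clear the scatter. The expected step is a 1.7-fold higher number from compound 2 to compound 4 (0.24 log units; within the scatter). Compound 4 is therefore estimated at 15000 nM, within a range from 5000 nM to 50000 nM.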

Compound 4, half-maximal inhibitory concentration: 5900 nM
Compound 4: the middle estimate sits 2.5-fold (0.41 log units) above what was measured, within the range that was stated.
By their numbers in this assay, from the lowest: compounds 4, 2 and 1 (each within the scatter of the next); then compound 3.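

In this assay fluoro in place of nitro on an aromatic carbon of the six-membered aromatic ring gives a 1.5-fold lower number from compound 2 to compound 4 (0.16 log units; within the scatter), so the two values cannot be put in order. Nitro, with 3 heavy atoms and 2 hydrogen-bond acceptors, and fluoro, with 1 heavy atom and no hydrogen-bond acceptors, thus give values within the scatter of each other at this position, which shows that the nitro group is not required for a value of this size in the series. Nothing available explains why this exchange leaves the values within the scatter.

The compounds shown leave open whether any group at this aromatic carbon would give a step beyond the scatter, for instance an amine, a carboxylic acid, a methoxy group or simply a hydrogen atom. They also leave open whether fluoro or nitro on a different aromatic carbon of the same ring would give a value close to those seen here, or one that clearly differs from them.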